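This account rests on a few compounds, and the source may have more. Where it says the series, first, only, none or still open, it means among the compounds named here.

Working notes on the series. In an assay on CHO cells for displacement of a labelled ligand from prostaglandin E2 receptor EP3 subtype (Homo sapiens), read by radioligand binding (on this read-out higher numbers stand for weaker inhibition and lower numbers for stronger inhibition), compound 2 `CC(C)C(c1ccc(-c2ccc3cccc(F)c3c2)[nH]c1=O)N1CCCCS1(=O)=O` gives 14 nM, the lowest of the three numbers. Compound 1 `CCC(CC)(c1nnc[nH]1)c1ccc(-c2ccc3cc(F)cc(F)c3c2)[nH]c1=O` is nearest, giving 89 nM in this assay, a gap beyond the scatter. Compound 3 `CC(C)C(O)(C(=O)O)c1ccc(-c2ccc3ccccc3c2)[nH]c1=O` is furthest, giving 544 nM in this assay, again beyond the scatter.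

Compound 4 `CC(C)C(c1ncco1)c1ccc(-c2ccc3cccc(F)c3c2)[nH]c1=O` is not yet measured. It differs from compound 2 in one place: a group of 5 heavy atoms (3 carbon, 1 nitrogen, 1 oxygen; one five-membered aromatic ring with 2 hetero atoms) in place of a group of 8 heavy atoms (4 carbon, 1 nitrogen, 2 oxygen, 1 sulfur; one six-membered non-aromatic ring with 2 hetero atoms), on a saturated chain carbon bound to an aromatic carbon and a saturated chain carbon, a 1,3-oxazol-2-yl in place of the six-membered non-aromatic ring, on the saturated chain carbon bound to an aromatic carbon and a saturated chain carbon. Within the data shown here, no pair of measured compounds shows this step. Among the measured compounds shown here, compound 1, carrying a different five-membered aromatic ring with hetero atoms on a chain carbon, gives 89 nM in this assay, and this is the only guide. The expected step from compound 2 to compound 4 is therefore a 3.6-fold higher number from compound 2 to compound 4 (0.55 log units; beyond the scatter), a weakening that may or may not exceed the scatter. For compound 4 the estimate in this assay is 50 nM, within a range of 12 nM to 200 nM.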

Compound 4, inhibition constant: 24 nM
Beside the measured number, compound 4's estimate is 2.1-fold (0.32 log units) above it; the measured number falls inside the stated range.
By their numbers in this assay, from the lowest: compounds 2 and 4 (each within the scatter of the next); then compound 1; then compound 3.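

On the saturated chain carbon bound to an aromatic carbon and a saturated chain carbon, replacing the six-membered non-aromatic ring with 1,3-oxazol-2-yl gives a 1.7-fold higher number from compound 2 to compound 4 (0.23 log units; within the scatter) in this assay. This position therefore holds either group on this read-out, an aromatic five-membered ring of 5 heavy atoms as well as a non-aromatic six-membered ring of 8 heavy atoms, and the sulfur of the leaving group is not needed to keep the number in this range. No measurement here gives a reason for this result.

As far as these compounds go, whether an amine or a carboxylic acid on this same carbon would stay within the scatter of compound 2 remains open. Also open, from the compounds shown here alone, is whether a 1,3-thiazol-2-yl or an open-chain sulfonamide here would do the same.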